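Methoxymethyl for Cyclopropyl at an Amide Carbonyl

The compounds below may be only part of what the source reports. "The series", "measured", "known", "first", "only" and "open" are said of these compounds alone.

compound 1 `CCC(=O)NCc1ccc2c(c1)CCN2C(=O)c1ccccc1`: 41%
compound 2 `CC(C)CC(=O)N1CCc2cc(CNC(=O)C3CC3)ccc21`: 35%

In an assay on HEK293 cells for inhibition of Indoleamine 2,3-dioxygenase 1 (Homo sapiens), tested at 10 uM (a higher number here means more inhibition at the concentration tested (going by the name of the read-out), a lower number less inhibition), compound 1 gives 41%, and compound 2 gives 35%. Compound 2 stands lowest of the two numbers, but its nearest neighbour, compound 1, sits only a little higher and within the scatter, so no order between the two can be claimed. Compound 3 `COCC(=O)NCc1ccc2c(c1)CCN2C(=O)CC(C)C` has not been measured. It differs from compound 2 in one place: methoxymethyl in place of cyclopropyl on a carbonyl carbon. For the measured compounds named here, no pair of measured compounds differing in a single place is available, so no step size can be read from the data. Compound 3 is therefore expected to lie close to compound 2, with a step of a number 3 percentage points lower from compound 2 to compound 3 (within the scatter) that is not expected to exceed the scatter in either direction. The estimate for compound 3 in this assay is 32%, between 15% and 50%.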

Compound 3, a percentage reported as inhibition, at one concentration (the size of the read-out at that concentration, not a potency): 20%
Compound 3: middle estimate off by 12 percentage points, on the high side, and the stated range covers the measured number.
By their numbers in this assay, from the lowest: compound 3; then compounds 2 and 1 (each within the scatter of the next).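

For the compounds shown here, at the carbonyl carbon whose other neighbour is an amide-type nitrogen, replacing cyclopropyl with methoxymethyl gives the first step that can be read in this assay: a number 15 percentage points lower from compound 2 to compound 3 (beyond the scatter). The position is therefore not indifferent to the group it carries, even though the two groups have the same count of heavy atoms and differ only in the ring that leaves and the oxygen that enters. Nothing available here accounts for the size or direction of this step.

Going by these compounds alone, the single step does not separate the loss of the ring from the gain of the oxygen, and a propyl chain or an oxetanyl ring on the same carbonyl carbon would bear on that question. Going by these compounds, how an amine or a carboxylic acid would read out at this place also remains open.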